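Swapping methyl for fluoro on the aromatic ring

The compounds below may be only part of what the source reports. "The series", "measured", "known", "first", "only" and "open" are said of these compounds alone.

Measured in a functional assay on the whole organism for antagonist activity, with Mus musculus as the target, in the maximal electroshock model; a higher number here means that more compound is needed for the effect, a lower number that less compound is needed:
compound 1 `COC(=O)NC1=NC(c2ccccc2F)CN1` gives 54 mg/kg
compound 2 `COC(=O)NC1=NC(c2ccccc2)CN1C` gives 107 mg/kg
compound 3 `COC(=O)NC1=NC(c2ccccc2C)CN1C` gives 68 mg/kg

Compound 3 lies within the usual scatter of both other compounds in this assay. Compound 4 `COC(=O)NC1=NC(c2ccccc2F)CN1C` differs from it by one change: fluoro in place of methyl on an aromatic carbon. Going by the values given here, the only measured step on this ring is a 1.6-fold lower number from compound 2 to compound 3 (0.20 log units; within the scatter), methyl in place of hydrogen on an aromatic carbon, and it stays within the scatter. Compound 1 already carries fluoro and gives 54 mg/kg, within the scatter of compound 3. No step beyond the scatter is therefore expected in this assay, and no direction can be favoured. The expected change is a 1.1-fold lower number from compound 3 to compound 4 (0.04 log units; within the scatter). For compound 4 the estimated value is 62 mg/kg, with an expected range from 32 mg/kg to 115 mg/kg.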

Compound 4, dose for half-maximal effect: 74 mg/kg
The estimate for compound 4 lay 1.2-fold (0.08 log units) below the measured number; low and high end bracket the measured number.
By their numbers in this assay, from the lowest: compounds 1, 3, 4 and 2 (each within the scatter of the next).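

Fluoro in place of methyl on this aromatic carbon gives a 1.1-fold higher number from compound 3 to compound 4 (0.04 log units; within the scatter) in this assay and leaves the two groups indistinguishable there. Fluoro in place of hydrogen on the same carbon gives a 1.4-fold lower number from compound 2 to compound 4 (0.16 log units; within the scatter) and methyl in place of hydrogen on the amine nitrogen in the ring gives a 1.4-fold higher number from compound 1 to compound 4 (0.14 log units; within the scatter) so neither change moves the number beyond the scatter.

As far as these compounds go, whether another group on this carbon, such as methoxy or an amine, would produce a step beyond the scatter stays open. No further measurement is at hand that bears on these numbers.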